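The source may hold more compounds than are shown below. What is called first, only, known or untested is meant among the compounds shown, and "the series" means these compounds.

Measured in a functional assay on CWR22R cells (Homo sapiens) for antiproliferative activity, read by propidium iodide staining, with a stated time of 96 h; a lower number here means a stronger inhibitor, a higher number a weaker inhibitor:
Compound 1 `CC(O)(COc1cccc(C(F)(F)F)c1)C(=O)Nc1cccc(S(F)(F)(F)(F)F)c1` gives 28900 nM
Compound 2 `CC(O)(COc1ccccc1C(F)(F)F)C(=O)Nc1cccc(S(F)(F)(F)(F)F)c1` gives 34900 nM
Compound 3 `CC(O)(COc1ccccc1OC(F)(F)F)C(=O)Nc1cccc(S(F)(F)(F)(F)F)c1` gives 30000 nM

Compound 2 stands level with the other two compounds, since both measured steps, a 1.2-fold higher number from compound 1 to compound 2 (0.08 log units; within the scatter) and a 1.2-fold lower number from compound 2 to compound 3 (0.07 log units; within the scatter), lie within the scatter. Compound 4 `CC(O)(COc1ccc(C#N)cc1C(F)(F)F)C(=O)Nc1cccc(S(F)(F)(F)(F)F)c1` has cyano in place of hydrogen on an aromatic carbon. Those two steps bear on it only loosely: they concern the trifluoromethyl group, and neither adds cyano. The data therefore show no direction, and no step beyond the scatter is expected in this assay. The expected step is a 1.4-fold lower number from compound 2 to compound 4 (0.14 log units; within the scatter). For compound 4 the estimated value is 25000 nM, with an expected range from 8000 nM to 50000 nM.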

Compound 4, half-maximal inhibitory concentration: 18300 nM
Estimate against measurement, compound 4: 1.4-fold (0.14 log units) above, and the stated range covers the measured number.
By their numbers in this assay, from the lowest: compounds 4, 1, 3 and 2 (each within the scatter of the next).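

With a cyano group on an aromatic carbon, meta to a trifluoromethyl group and para to a large group, this assay gives a 1.9-fold lower number from compound 2 to compound 4 (0.28 log units; within the scatter). Compounds 1, 2 and 3 differed only in the placement or kind of the fluorinated group, whereas this change adds a nitrile to the ring and still leaves the number within the scatter of compound 2. Nothing at hand explains the result. On these data alone, whether an amine or a carboxylic acid on this same carbon would move the number beyond the scatter stays open, as does the effect of cyano at other ring positions.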